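Aryl Exchange on the Ring Nitrogen: Compound 3 to Compound 4

The compounds below may be only part of what the source reports. "The series", "measured", "known", "first", "only" and "open" are said of these compounds alone.

Three compounds have been measured in a functional assay on HepG2 cells (Homo sapiens) for inhibition, read by MTT assay, with a stated time of 72 h, tested at 50 uM; on this read-out lower numbers stand for less inhibition of growth and higher numbers for more inhibition of growth at the one concentration tested:
compound 1 `C=CCc1ccc(OCc2cn(-c3ccccc3CO)nn2)c(O)c1` gives 8.5%
compound 2 `C#CCOc1ccc(CC=C)cc1O` gives 5.6%
compound 3 `C=CCc1ccc(OCc2cn(-c3cccc(C#N)c3)nn2)c(O)c1` gives 3.4%

Compound 3 stands at the lowest of the three numbers; its nearest neighbour is compound 2 and its furthest is compound 1, and both gaps lie within the scatter, so none of the three can be set apart from the others. Going by the values given here, the only measured step that exchanges the aryl group on the aromatic nitrogen is a number 5.1 percentage points lower from compound 1 to compound 3 (within the scatter), which also lies within the scatter.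

Compound 4 `C=CCc1ccc(OCc2cn(-c3ccc(Br)cc3)nn2)c(O)c1` differs from compound 3 in one place: 4-bromophenyl in place of 3-cyanophenyl on an aromatic nitrogen. Among the compounds with values here, this is again an exchange of the aryl group on the aromatic nitrogen, and the one step of that kind stayed within the scatter; compound 2, with a different arm on the shared core, also sits close to compound 3. In this assay no step beyond the scatter is therefore expected, and compound 4 is estimated at 5.5%, within 0% to 15%. The expected step is a number 2.1 percentage points higher from compound 3 to compound 4 (within the scatter).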

Compound 4, percent growth inhibition at one concentration: 9.5%
Estimate against measurement, compound 4: 4 percentage points below, within the range that was stated.
By their numbers in this assay, from the lowest: compounds 3, 2, 1 and 4 (each within the scatter of the next).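

In this assay the exchange to 4-bromophenyl on the aromatic nitrogen gives a number 6.1 percentage points higher from compound 3 to compound 4 (within the scatter) and also a number 1 percentage points higher from compound 1 to compound 4 (within the scatter) as its two steps. The earlier compounds shown here offered a single step of this kind, whereas compound 1, compound 3 and compound 4 now give three steps among three aryl groups, carrying a hydroxymethyl, a nitrile or a bromine. None of these exchanges on the aromatic nitrogen moves the number beyond the scatter at the one concentration tested, so the three aryl groups cannot be told apart here.

As far as these compounds go, whether an aryl group carrying an amine or a carboxylic acid, or a longer chain on this nitrogen, would give a step beyond the scatter remains open. Nothing shown here offers an explanation for these numbers.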